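Working notes: tert-butyl to methoxy swap on the aryl ring

A few compounds are considered here, and "the series" means these few. Any claim that something is new, unique, unknown or untested is made for them only; others in the source may bear on it.

Measured so far in an assay on cells for inhibition of Palmitoleoyl-protein carboxylesterase NOTUM variant C330S (Homo sapiens), read by fluorescence, with a stated time of 40 min; a higher number here means a weaker inhibitor, a lower number a stronger inhibitor:
compound 1 `Cc1cc(C(=O)O)c(C)n1-c1cccc(Cl)c1`: 430 nM
compound 2 `Cc1cc(C(=O)O)c(C)n1-c1cccc(C(C)(C)C)c1`: 460 nM

Compound 2 carries the higher of the two numbers, yet the step of a 1.1-fold higher number from compound 1 to compound 2 (0.03 log units; within the scatter) shows that exchanging chloro for tert-butyl at this carbon leaves the read-out essentially unchanged. Compound 3 `COc1cccc(-n2c(C)cc(C(=O)O)c2C)c1` differs from compound 2 by methoxy in place of tert-butyl on an aromatic carbon. Among the compounds with values here, no measured step addresses methoxy at this position; the only related step, a 1.1-fold higher number from compound 1 to compound 2 (0.03 log units; within the scatter), suggests that substituents here move the number little. A step of about a 1.3-fold higher number from compound 2 to compound 3 (0.12 log units; within the scatter) in this assay is therefore expected, with no clear direction beyond the scatter. The estimate for compound 3 is 600 nM, range 250 nM to 1500 nM.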

Compound 3, half-maximal inhibitory concentration: 1500 nM
Beside the measured number, compound 3's estimate is 2.5-fold (0.40 log units) below it; the measured number falls inside the stated range.
By their numbers in this assay, from the lowest: compounds 1 and 2 (each within the scatter of the next); then compound 3.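

In this assay, the group on this aromatic carbon does affect the number: methoxy gives a 3.3-fold higher number from compound 2 to compound 3 (0.51 log units; beyond the scatter) and a 3.5-fold higher number from compound 1 to compound 3 (0.54 log units; beyond the scatter), whereas the exchange of chloro for tert-butyl gives only a 1.1-fold higher number from compound 1 to compound 2 (0.03 log units; within the scatter). Among these three compounds, the tolerance seen with chloro and tert-butyl therefore does not extend to methoxy, and compound 3 is the weakest inhibitor. No measurement at hand gives a cause for this difference.

Open, on these data alone, is whether a hydroxyl group or an amine on this carbon would track with methoxy or with chloro and tert-butyl. Also open, as far as these compounds go, is whether a longer chain such as ethoxy would shift the number further.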